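Trimming a Methoxy from Compound 2

A few compounds are considered here, and "the series" means these few. Any claim that something is new, unique, unknown or untested is made for them only; others in the source may bear on it.

Compound 1 `COc1cc(-c2cc(/C=C/C(=O)c3ccc(Cl)c(Cl)c3)[nH]n2)cc(OC)c1OC`: > 100000 nM
Compound 2 `COc1ccc(C(=O)/C=C/c2cc(-c3cc(OC)c(OC)c(OC)c3)n[nH]2)cc1OC`: 3050 nM

Two compounds share a core and differ only in the ring on the carbonyl carbon. In a functional assay on HT-29 cells (Homo sapiens) for inhibition, read by sulforhodamine B assay, with a stated time of 48 h (a lower number here means a stronger inhibitor of growth, a higher number a weaker inhibitor of growth), compound 1 gives only a limit, > 100000 nM. In this assay, among the measured compounds shown here, compound 2 gives 3050 nM, the only number among the two values. The other value, that of compound 1, is a limit (the limit of > 100000 nM in this assay, at which 1 of the 2 values shown sits). The step of an at least 32-fold lower number from compound 1 to compound 2 (1.51 log units; beyond the scatter) is therefore bounded from below, not known exactly.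

Compound 3 `COc1ccc(C(=O)/C=C/c2cc(-c3cc(OC)c(OC)c(OC)c3)n[nH]2)cc1` is not yet measured. It differs from compound 2 by hydrogen in place of methoxy on an aromatic carbon. For the measured compounds named here, no measured step removes a single methoxy from this ring; the one step seen exchanged the whole 3,4-dichlorophenyl for 3,4-dimethoxyphenyl and was large. That step says compound 2 sits well away from the limit, but it does not say how much one methoxy contributes. A modest weakening, or a change within the scatter, is expected for compound 3, a 1.6-fold higher number from compound 2 to compound 3 (0.21 log units; within the scatter). Compound 3 is therefore estimated at 5000 nM, within 1500 nM to 20000 nM.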

Compound 3, concentration for total growth inhibition: 4190 nM
Beside the measured number, compound 3's estimate is 1.2-fold (0.08 log units) above it; the measured number falls inside the stated range.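

Cutting the 3,4-dimethoxyphenyl back to 4-methoxyphenyl gives a 1.4-fold higher number from compound 2 to compound 3 (0.14 log units; within the scatter), so in this assay the loss of this one methoxy, ortho to a methoxy group, cannot be told from the scatter. The large step away from the 3,4-dichlorophenyl compound therefore does not depend on having both methoxy groups on this ring, as the version with a single methoxy still shows an at least 23-fold lower number from compound 1 to compound 3 (1.37 log units; beyond the scatter). This step, like the earlier one, is bounded from one side only, and compound 1 gives only a limit in this assay: the limit of > 100000 nM in this assay, at which 1 of the 3 values shown sits.

The compounds shown leave open what the remaining methoxy contributes, and whether a plain phenyl, or a hydroxyl or an amine in its place, would keep the number near those of compound 2 and compound 3. Among the compounds shown here, they also leave open how a single chlorine on this ring would read, given that compound 1 carries two chlorine atoms and so differs from compound 3 in more than the one group that stays.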